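Swapping an Isopropyl Group for an Aminomethyl Group

The source may hold more compounds than are shown below. What is called first, only, known or untested is meant among the compounds shown, and "the series" means these compounds.

Compound 1 `CC(C)C(NC(=O)c1ccc(C#Cc2ccccc2)cc1)C(=O)NO` is one of three hydroxamic acids that share the same core and the same phenylethynyl-substituted benzamide arm. In a physicochemical assay for lipophilicity (a higher number here means a more lipophilic compound, a lower number a more polar compound), compound 1 gives > 3, which is a limit of the assay rather than a number. Compound 2 `O=C(NC1(C(=O)NO)CCCCC1)c1ccc(C#Cc2ccccc2)cc1` also gives > 3 in this assay, again a limit. Compound 3 `O=C(NC1(C(=O)NO)CCN(Cc2ccccc2)CC1)c1ccc(C#Cc2ccccc2)cc1` likewise reaches only > 3 in this assay, a limit as well. All three known values thus sit at the limit of > 3 in this assay, at which 3 of the 3 values shown sit, so compound 1 cannot be placed above or below its two companions; the measurements simply stopped at the same point.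

Compound 4 `NC[C@H](NC(=O)c1ccc(C#Cc2ccccc2)cc1)C(=O)NO` has not yet been measured in this assay. It differs from compound 1 in a single place: a group of 7 heavy atoms (3 carbon, 2 nitrogen, 2 oxygen; no ring) in place of a group of 8 heavy atoms (5 carbon, 1 nitrogen, 2 oxygen; no ring), on an amide-type nitrogen. Within the data shown here, no step between two measured compounds is available to calibrate this change, so the expectation rests on the change alone. A clear fall in this assay is expected from compound 1 to compound 4, namely a number at least 2.00 log units lower from compound 1 to compound 4 (beyond the scatter). For compound 4 the estimated value is 1, expected to lie between 0 and 2.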

Compound 4, distribution coefficient: 2
Estimate against measurement, compound 4: 1.00 log units below, and the stated range covers the measured number.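

In this assay the change on the amide-type nitrogen, from 1-(hydroxycarbamoyl)-2-methylpropyl to the group carrying an aminomethyl side chain, gives a number at least 1.00 log units lower from compound 1 to compound 4 (beyond the scatter) and not merely another limit. Among these compounds, compound 4 is the only compound here whose result is a number: (the limit of > 3 in this assay, at which 3 of the 4 values shown sit). This position is therefore one where a single change can bring a compound into the range that the measurement can read, which compound 1, compound 2 and compound 3 could not show.

Going by these compounds, for compound 1 the result > 3 is a limit, and the full size of the step stays unknown. Whether the amine itself accounts for the step stays open, and a hydroxymethyl group, a carboxylic acid or a longer chain ending in an amine at this place would help to tell.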